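This account rests on a few compounds, and the source may have more. Where it says the series, first, only, none or still open, it means among the compounds named here.

Two compounds in this set have been run in an assay on HEK293 cells for activation of Kir3.1/Kir3.2 (Homo sapiens), read by thallium flux; a lower number here means a smaller maximal response, a higher number a larger maximal response. Compound 1 `Cc1cc(NC(=O)Cn2nnc(-c3ccccc3)n2)n(C2CCS(=O)(=O)CC2)n1` carries a phenyl group on the five-membered aromatic ring and a sulfone-bearing ring on the core; for compound 1 this assay reports only a limit of > 25% and not a number, which is the situation described as the limit of > 25% in this assay, at which 1 of the 2 values shown sits. Compound 2 `Cc1cc(NC(=O)Cn2nnc(-c3ccc(Cl)c(Cl)c3)n2)n(C2CCCCC2)n1` instead carries a 3,4-dichlorophenyl group and a cyclohexyl ring, and in this assay compound 2 gives 84%, the only full number shown in this series.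

Compound 3 `Cc1cccc(-c2nnn(CC(=O)Nc3cc(C)nn3C3CCCCC3)n2)c1` is not yet measured. It differs from compound 2 in one place: 3-methylphenyl in place of 3,4-dichlorophenyl on an aromatic carbon. Within the data shown here, no measured pair in this set shows what such a swap does, so the size of the step is open. The two chlorines leave and a single methyl enters, and the expectation here is a modest step down from compound 2 to compound 3 of a number 16 percentage points lower from compound 2 to compound 3 (beyond the scatter), possibly beyond the usual scatter. Compound 3 is therefore estimated at 68% in this assay, within a range from 45% to 92%.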

Compound 3, largest response reached (Emax), in percent of the reference or control that the assay uses: 93%
Compound 3: middle estimate off by 25 percentage points, on the low side, and the stated range ends below it.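

In this assay, among these compounds, the only swap measured at this aromatic carbon of the five-membered ring gives a number 9 percentage points higher from compound 2 to compound 3 (within the scatter), a step that stays within the usual scatter. The two chlorines of 3,4-dichlorophenyl can therefore give way to the single methyl of 3-methylphenyl without a readable change in maximal response, so compound 2 and compound 3 cannot be told apart here, though this holds only for this pair, with its cyclohexyl ring. Nothing measured here explains why the two groups read alike.

As far as these compounds go, what a methoxy group or an amine would do on this phenyl ring remains open. Among the compounds shown here, the role of the cyclohexyl ring is open too: compound 1 differs from compound 2 in more than one place, so no step to compound 1 can be read.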